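Working notes: cytotoxicity of compounds 1 to 4

A few compounds are considered here, and "the series" means these few. Any claim that something is new, unique, unknown or untested is made for them only; others in the source may bear on it.

Measured so far:
compound 1 `COC(=O)c1cccc(NC(=O)C2CCCN(C(=O)c3cc(C(F)(F)F)cc(C(F)(F)F)c3)C2)c1`: 0%
compound 2 `C=Cc1cccc(C(=O)N2CCCC(C(=O)Nc3ccc(Cl)cc3)C2)c1`: 0%
compound 3 `COc1cccc(C(=O)N2CCCC(C(=O)Nc3ccc(Cl)cc3)C2)c1`: 0%

In an ADME assay on PC-3 cells (Homo sapiens) for cytotoxicity, read by WST assay, tested at 100 uM (a lower number here means less inhibition, a higher number more inhibition at the concentration tested (going by the name of the read-out)), compound 1 gives 0%. Compound 2 gives 0% and compound 3 gives 0%, so compound 1 stands level with both at the digits shown. Within the data shown here, the single measured step, no change at the digits printed from compound 2 to compound 3 (within the scatter), swaps one small group on an aromatic carbon and leaves the read-out flat.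

Compound 4 `C=CCOc1cccc(NC(=O)C2CCCN(C(=O)c3cc(C(F)(F)F)cc(C(F)(F)F)c3)C2)c1` differs from compound 1 by allyloxy in place of methoxycarbonyl on an aromatic carbon. Among the measured compounds shown here, no measured step covers this exchange on the shared core; the only comparable step was flat, and all three compounds sit at the same level, so the expected step is no change at the digits printed from compound 1 to compound 4 (within the scatter), none beyond the scatter. Compound 4 is estimated at 0%, between -5% and 12%.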

Compound 4, a percentage reported as inhibition, at one concentration (the size of the read-out at that concentration, not a potency): 0%
Beside the measured number, compound 4's estimate shows no gap at the digits printed; the range from low to high includes it.
By their numbers in this assay, from the lowest: compounds 1, 2, 3 and 4 (each within the scatter of the next).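

At the aromatic carbon meta to a large group, allyloxy in place of methoxycarbonyl gives no change at the digits printed from compound 1 to compound 4 (within the scatter) in this assay. This extends the flat read-out from the small-group exchange on the other series to a different group on the core of compound 1, with one hydrogen-bond acceptor fewer in the entering group. Nothing available accounts for the flat result. From the compounds shown here alone, whether an amine or a carboxylic acid on this aromatic carbon would depart from compound 4, at 0%, stays open. Going by these compounds, a longer chain at this place is equally open.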